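Adding a hydroxy group to a weak topoisomerase inhibitor

This account rests on a few compounds, and the source may have more. Where it says the series, first, only, none or still open, it means among the compounds named here.

Of the compounds shown here, three have so far been tested in an assay on isolated protein for inhibition of DNA topoisomerase 1 (Homo sapiens), tested at 20 uM; a higher number here means a stronger effect of the compound at the concentration tested, a lower number a weaker effect. Compound 1 `O=C(/C=C/c1ccc(N2CCCC2)cc1)c1ccc([N+](=O)[O-])cc1` gives 77.6%, and compound 3 `O=C(/C=C/c1ccc(N2CCCC2)cc1)c1ccc(O)cc1O` gives 64.4%. Compound 2 `COc1ccc(/C=C/C(=O)c2ccc(O)cc2)cc1Br` gives 6.6% in this assay and stands lowest of the three: the nearest number is that of compound 3, which lies higher by an amount beyond the usual scatter, and the number of compound 1 lies further above still. No pair among these three differs in only one place, so no single structural step has yet been measured.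

The next compound, compound 4 `COc1ccc(/C=C/C(=O)c2ccc(O)cc2O)cc1Br`, differs from compound 2 in one place: hydroxy in place of hydrogen on an aromatic carbon. Compound 4 shares everything else with compound 2, so its result in this assay will show what this one change does on its own.

Among the measured compounds shown here, with no measured step of this kind to lean on, and compound 2 starting from a very low number, the writer expects at most a modest rise for compound 4 in this assay, so that the step of a number 5.4 percentage points higher from compound 2 to compound 4 (within the scatter) is estimated to stay close to the scatter. Compound 4 is therefore estimated at 12%, with a range from 0% to 35%.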

Compound 4, a percentage reported as inhibition, at one concentration (the size of the read-out at that concentration, not a potency): 8.2%
For compound 4 the middle estimate is 3.8 percentage points above the measured one, and the stated range covers the measured number.
By their numbers in this assay, from the lowest: compounds 2 and 4 (each within the scatter of the next); then compound 3; then compound 1.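

Among the compounds shown here, the step is a number 1.6 percentage points higher from compound 2 to compound 4 (within the scatter), the first measured step in this assay that changes one place only. On the core of compound 2, hydroxy in place of hydrogen on this aromatic carbon, ortho to a large group and meta to a hydroxy group, therefore gives no readable difference, and compound 2 and compound 4 stand together at the bottom of the four numbers. Nothing measured here offers an explanation for this result.

Compound 3 carries a hydroxy group at the same place, but it has no partner among the compounds shown that differs from it only there, so what the group contributes on that core remains open. Also open, as far as these compounds go, is whether a different group on this aromatic carbon of compound 2, such as an amine or a carboxylic acid, would produce a step beyond the scatter, or whether this position gives little response to any change.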